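A few compounds are considered here, and "the series" means these few. Any claim that something is new, unique, unknown or untested is made for them only; others in the source may bear on it.

In a functional assay on HeLa cells (Homo sapiens) for inhibition (a lower number here means a stronger inhibitor, a higher number a weaker inhibitor), compound 1 (`O=C/C=C/n1c(=O)ccn([C@H]2C[C@H](O)[C@@H](CO)O2)c1=O`) gives 15000 nM. Compound 2 (`CC(=O)/C=C/n1c(=O)ccn([C@H]2C[C@H](O)[C@@H](CO)O2)c1=O`) gives > 100000 nM, which is a limit of the assay and not a number. Compound 2 therefore has no exact standing, and all that is known is that it lies on the weak side of compound 1. For the measured compounds named here, the only measured step is an at least 6.6-fold higher number from compound 1 to compound 2 (0.82 log units; beyond the scatter), and it came with methyl in place of hydrogen on a carbonyl carbon.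

Compound 3 (`N#C/C=C/n1c(=O)ccn([C@H]2C[C@H](O)[C@@H](CO)O2)c1=O`) carries cyano in place of acetyl on a double-bonded chain carbon bound to a double-bonded chain carbon. The measured step bears on this change only indirectly, as it is the step that introduced the acetyl group now leaving. With acetyl gone, a partial return towards compound 1 is expected in this assay, so the number should move lower, by an amount no larger than the measured step. A second reading at the limit remains possible. The expected change is an at least 2.5-fold lower number from compound 2 to compound 3 (0.39 log units; beyond the scatter). For compound 3 the estimated value is 40000 nM, with an expected range from 10000 nM to 120000 nM.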

Compound 3, half-maximal inhibitory concentration: > 100000 nM
Compound 3: a limit, no number (the forecaster's own chance of this, stated with the estimate: 40%); middle value at least 2.5-fold (0.39 log units) from the limit.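

In this assay, exchanging formyl for cyano gives an at least 6.6-fold higher number from compound 1 to compound 3 (0.82 log units; beyond the scatter). Acetyl is therefore no longer the only replacement for formyl at this place that leaves the compound on the weak side of compound 1, and among the three groups shown only formyl gives a value that is a number. The step between compound 2 and compound 3 cannot be read, because both values are limits of the assay and not numbers: the limit of > 100000 nM in this assay, at which 2 of the 3 values shown sit.

Going by these compounds, how far compound 2 and compound 3 lie beyond their shared limit stays unknown, so no order can be given between acetyl and cyano. Also open, on these data alone, is whether another group at this place, such as a carboxylic acid, an amide or a longer chain ending in formyl, would reach or pass compound 1 at 15000 nM.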